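Mirror Images in a Long-Chain Stereoisomer Series

The source may hold more compounds than are shown below. What is called first, only, known or untested is meant among the compounds shown, and "the series" means these compounds.

Compound 1 `CCCCCCCCCCCCCC[C@@H]1N[C@@H](CO)[C@@H]1O`: 4.5 ug/mL
Compound 2 `CCCCCCCCCCCCCC[C@@H]1N[C@H](CO)[C@H]1O`: 4.5 ug/mL

Both compounds were tested in a functional assay on L1210 cells (Mus musculus) for cytotoxicity; on this read-out higher numbers stand for weaker inhibition and lower numbers for stronger inhibition. There, compound 2 gives 4.5 ug/mL, level with compound 1 at the digits shown, and it has no other neighbour to be compared with. The next structure is compound 3 `CCCCCCCCCCCCCC[C@H]1N[C@@H](CO)[C@@H]1O`, still to be measured in this assay. The change is the two compounds have the same atoms and bonds and differ only in configuration as drawn: 3 of 3 stereo elements differ (all stereocentres are inverted: mirror images); a stereocentre at a saturated ring carbon is drawn S in compound 2 and R in compound 3; a stereocentre at a saturated ring carbon is drawn R in compound 2 and S in compound 3; a stereocentre at a saturated ring carbon is drawn S in compound 2 and R in compound 3. Nothing leaves and nothing enters, so only the drawn configuration separates the pair.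

Among the compounds with values here, one measured step bears on this, and it shows no change at the digits printed from compound 1 to compound 2 (within the scatter). Behind that step lies (the fact that compounds 1 and 2 differ only in the configuration as drawn). It inverted two of the three stereo elements, so it tests only part of the change now in question, and it is a single observation. Even so, it gives no reason to expect movement. For this assay, the expected result is no step beyond the scatter, with an estimated no change at the digits printed from compound 2 to compound 3 (within the scatter). Compound 3 is expected at 4.5 ug/mL, with an estimated range of 2 ug/mL to 10 ug/mL.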

Compound 3, half-maximal inhibitory concentration: 1.6 ug/mL
For compound 3 the middle estimate is 2.8-fold (0.45 log units) above the measured one, outside the stated range (below it).
By their numbers in this assay, from the lowest: compound 3; then compounds 1 and 2 (each within the scatter of the next).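

In this assay the two mirror images do not read alike, with a 2.8-fold lower number from compound 2 to compound 3 (0.45 log units; beyond the scatter), so this cytotoxicity read-out can tell the two hands of this structure apart, which the earlier pair could not show: the fact that compounds 2 and 3 differ only in the configuration as drawn

The earlier step, no change at the digits printed from compound 1 to compound 2 (within the scatter), had inverted two stereocentres without visible effect, whereas inverting only the remaining stereocentre, at a saturated ring carbon, gives a 2.8-fold lower number from compound 1 to compound 3 (0.45 log units; beyond the scatter), a modest step but one beyond the scatter: the fact that compounds 1 and 3 differ only in the configuration as drawn

Among the three compounds, the configuration at that single stereocentre is therefore the only difference that goes with a shift in the read-out, and compound 3 has the lowest number, with both of its steps beyond the scatter.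

The compounds shown leave open how the mirror image of compound 1 would read, and so whether the effect of that stereocentre holds when the other two are inverted in the opposite sense. They also leave open whether the same preference would survive a longer chain, or a carboxylic acid or an amine on the shared core.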